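A few compounds are considered here, and "the series" means these few. Any claim that something is new, unique, unknown or untested is made for them only; others in the source may bear on it.

In a functional assay on HL-60 cells (Homo sapiens) for cytotoxicity, read by MTT assay, with a stated time of 48 h (a lower number here means a stronger inhibitor, a higher number a weaker inhibitor), the three measured compounds stand as follows. Compound 1 `CC(C)(C)c1ccc(OC(=O)c2cn(-c3ccccc3)nc2-c2cccnc2)cc1` gives > 100000 nM, which is a limit of the assay rather than a number. Compound 2 `Cc1ccc(C(C)C)c(OC(=O)c2cn(-c3ccccc3)nc2-c2cccnc2)c1` gives 22700 nM. Compound 3 `CC(C)(C)c1ccc(OC(=O)c2cn(-c3ccccc3)nc2-c2ccncc2)cc1` gives 18700 nM.

Compound 2 and compound 3 lie within the usual scatter of each other. The change from compound 1 to compound 2 is 2-isopropyl-5-methylphenyl in place of 4-(tert-butyl)phenyl on an oxygen next to a carbonyl group and it made an at least 4.4-fold lower number from compound 1 to compound 2 (0.64 log units; beyond the scatter); that step is known only as a limit because of the limit of > 100000 nM in this assay, at which 1 of the 3 values shown sits. The change of pyridin-3-yl to pyridin-4-yl made an at least 5.3-fold lower number from compound 1 to compound 3 (0.72 log units; beyond the scatter).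

Compound 4 `Cc1ccc(C(C)C)c(OC(=O)c2cn(-c3ccccc3)nc2-c2ccncc2)c1` has not been measured. It arises from compound 3 by 2-isopropyl-5-methylphenyl in place of 4-(tert-butyl)phenyl on an oxygen next to a carbonyl group, the same change as from compound 1 to compound 2, made on a core that differs from that of compound 1 by pyridin-4-yl in place of pyridin-3-yl on an aromatic carbon. For compound 4 a step of a 3.1-fold lower number from compound 3 to compound 4 (0.49 log units; beyond the scatter) from compound 3 is expected, resting on the earlier step of an at least 4.4-fold lower number from compound 1 to compound 2 (0.64 log units; beyond the scatter) and on compound 3 at 18700 nM. This expectation is held cautious since the earlier step from compound 1 to compound 2 is known only as a limit of the assay for compound 1. Compound 4 is thus estimated at 6000 nM, with a likely range from 1500 nM to 25000 nM.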

Compound 4, half-maximal inhibitory concentration: 17800 nM
Beside the measured number, compound 4's estimate is 3.0-fold (0.47 log units) below it; the measured number falls inside the stated range.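

In this assay, the swap to 2-isopropyl-5-methylphenyl gave a 1.1-fold lower number from compound 3 to compound 4 (0.02 log units; within the scatter), so the earlier step on the core of compound 1 did not carry over to this second core: the same change on two cores in this assay, an at least 4.4-fold lower number (0.64 log units; beyond the scatter) from compound 1 to compound 2 and a 1.1-fold lower number (0.02 log units; within the scatter) from compound 3 to compound 4, at least 4.1-fold (0.62 log units) apart, beyond the scatter of two such steps

The swap to pyridin-4-yl likewise gave a 1.3-fold lower number from compound 2 to compound 4 (0.11 log units; within the scatter), which does not repeat its earlier step: the same change on two cores in this assay, an at least 5.3-fold lower number (0.72 log units; beyond the scatter) from compound 1 to compound 3 and a 1.3-fold lower number (0.11 log units; within the scatter) from compound 2 to compound 4, at least 4.1-fold (0.62 log units) apart, beyond the scatter of two such steps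

Both earlier steps start from compound 1, which stands at a limit and not a number, so their true size stays unknown, and nothing here shows why the two changes do not add up: the limit of > 100000 nM in this assay, at which 1 of the 4 values shown sits.

Still open, on these data alone, is whether a phenyl ring carrying an amine or a carboxylic acid, placed on an oxygen next to a carbonyl group, would move the number.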